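Mirror-image pair in a series of low numbers

A few compounds are considered here, and "the series" means these few. Any claim that something is new, unique, unknown or untested is made for them only; others in the source may bear on it.

Measured so far in an assay on isolated protein for inhibition of alpha-mannosidase (Canavalia ensiformis), tested at 1000 uM; on this read-out higher numbers stand for more inhibition at the one concentration tested (going by the name of the read-out) and lower numbers for less inhibition:
- compound 1 `OC[C@@]1(c2ccc(O)cc2)NC[C@@H](O)[C@@H]1O`: 2.2%
- compound 2 `OC[C@]1(c2c(F)c(F)c(F)c(F)c2F)NC[C@H](O)[C@H]1O`: 6.6%

Compound 2 holds the higher of the two numbers in this assay, but the gap to compound 1 lies within the usual scatter, so the two read as alike. Both sit near the floor of the read-out.

Compound 3 `OC[C@@]1(c2c(F)c(F)c(F)c(F)c2F)NC[C@@H](O)[C@@H]1O` is the mirror image of compound 2: the two compounds have the same atoms and bonds and differ only in configuration as drawn: 3 of 3 stereo elements differ (all stereocentres are inverted: mirror images); a stereocentre at a saturated ring carbon is drawn S in compound 2 and R in compound 3; a stereocentre at a saturated ring carbon is drawn S in compound 2 and R in compound 3; a stereocentre at a saturated ring carbon is drawn S in compound 2 and R in compound 3. For the measured compounds named here, no step between two measured compounds is available to calibrate such a change, since compound 1 and compound 2 differ in more than one place, and their two values show no separation beyond the scatter. With compound 2 giving 6.6%, a low number, there is little room for a downward step, and nothing in the numbers at hand points to a large upward one. The step of a number 1.6 percentage points lower from compound 2 to compound 3 (within the scatter) is expected to stay within the scatter. Compound 3 is estimated at 5%, with a range from 0% to 15%.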

Compound 3, a percentage reported as inhibition, at one concentration (the size of the read-out at that concentration, not a potency): 0%
Beside the measured number, compound 3's estimate is 5 percentage points above it; the measured number falls inside the stated range.
By their numbers in this assay, from the lowest: compounds 3, 1 and 2 (each within the scatter of the next).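

In this assay, the pair gives the series its first calibrated step for a configuration change, a number 6.6 percentage points lower from compound 2 to compound 3 (within the scatter), and the two mirror images read as alike. With every stereocentre inverted and nothing else altered, the pair isolates configuration as the sole variable: the fact that compounds 2 and 3 differ only in the configuration as drawn

At this single high concentration, neither mirror image rises clear of the floor of the read-out, so the step shows no dependence on configuration, though a floor this low leaves little room for one to appear. On these data alone, whether configuration counts in a compound with a clearly higher number stays open. So does whether a carboxylic acid or a longer chain on the shared core would lift the number off the floor at all.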